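The source may report more compounds than this note shows. Statements on the series, on what has been measured and on what is new or still open speak of the compounds shown alone.

Compound 1 `O=C(NC/C=C\Cn1ccc(=O)[nH]c1=O)c1ccccc1`. In a functional assay on SW-620 cells (Homo sapiens) for cytotoxicity, read by MTT assay, with a stated time of 72 h (on this read-out higher numbers stand for weaker inhibition and lower numbers for stronger inhibition), compound 1 gives > 100000 nM, which is a limit of the assay.
Compound 2 `Cc1cn(C/C=C\CNC(=O)c2ccccc2)c(=O)[nH]c1=O`. In this assay compound 2 gives > 100000 nM, again a limit.
Compound 3 `O=C(NC/C=C\Cn1ccc(=O)[nH]c1=O)c1ccc(F)cc1`. In this assay compound 3 gives > 100000 nM, also a limit.

All three measured compounds share one core and stand at the same limit, (the limit of > 100000 nM in this assay, at which 3 of the 3 values shown sit), so none of them gives a number that can be placed. Within the data shown here, the step from compound 1 to compound 2 is a step that the two limits leave unreadable from compound 1 to compound 2, and the step from compound 1 to compound 3 is a step that the two limits leave unreadable from compound 1 to compound 3; neither tells how far either change moved the read-out, only that both compounds stay beyond what the assay reports.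

Compound 4 `Cc1cn(C/C=C\CNC(=O)c2ccc(F)cc2)c(=O)[nH]c1=O` is not yet measured. It differs from compound 3 by methyl in place of hydrogen on an aromatic carbon. Among the measured compounds shown here, the one measured step that bears on this change, from compound 1 to compound 2, is unreadable, and compound 3 itself stands only at a limit, so there is no number from which a direction or size in this assay could be read. The expected outcome for compound 4 is therefore that it too sits at the limit, an expected step that the limit leaves unreadable from compound 3 to compound 4. Compound 4 is estimated at 150000 nM, within 50000 nM to 500000 nM.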

Compound 4, half-maximal inhibitory concentration: > 100000 nM
Compound 4: only a limit was reported; the forecaster's own chance of this, stated with the estimate: 85%; the middle value is on the limit's open side.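

In this assay compound 4 gives > 100000 nM, again a limit and not a number. Neither the step from compound 3 to compound 4 nor the step from compound 2 to compound 4 can be read: the limit of > 100000 nM in this assay, at which 4 of the 4 values shown sit. The compounds shown leave open how far either methyl or fluoro in place of hydrogen moves the read-out, and whether this shared core can give a measurable value here.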